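The compounds below may be only part of what the source reports. "The series", "measured", "known", "first", "only" and "open" are said of these compounds alone.

Measured compounds:
- compound 1, `Cc1onc(NS(=O)(=O)c2ccc(N)cc2)c1I`: in an assay on COS-7 cells for displacement of a labelled ligand from Endothelin receptor type B (Sus scrofa) (a higher number here means a weaker inhibitor, a lower number a stronger inhibitor), compound 1 gives > 1000000 nM
- compound 2, `COc1cccc(Sc2c(NS(=O)(=O)c3ccc(C(C)(C)C)cc3)noc2C)c1`: in this assay compound 2 gives 300 nM
- compound 3, `CSc1c(NS(=O)(=O)c2ccc(C(C)(C)C)cc2)noc1C`: in this assay compound 3 gives 35000 nM

The value of compound 1 is a limit of the assay, not a number (the limit of > 1000000 nM in this assay, at which 1 of the 3 values shown sits). Among the two numbers, compound 3 holds the higher one, so it is the weaker inhibitor of the two; its nearest neighbour is compound 2, and the step of a 120-fold higher number from compound 2 to compound 3 (2.07 log units; beyond the scatter) is large and beyond the scatter.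

Compound 4, `Cc1onc(NS(=O)(=O)c2ccc(C(C)(C)C)cc2)c1I`, has not yet been measured. It differs from compound 3 in one place: iodo in place of methylsulfanyl on an aromatic carbon. Among the measured compounds shown here, this is the same position that changes in the only measured step, from compound 2 to compound 3, where a large aromatic group was replaced by a methyl on the sulfur and the number rose sharply. That step shows the position is sensitive, but it involves a sulfur substituent, not a halogen, so it gives only a rough guide. Since the methylsulfanyl group and the iodo group are both small, compound 4 is expected to stay close to compound 3, with a step of a 1.4-fold higher number from compound 3 to compound 4 (0.15 log units; within the scatter), and its expected value in this assay is 50000 nM, within 8000 nM to 300000 nM.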

Compound 4, half-maximal inhibitory concentration: 30000 nM
Compound 4: middle estimate off by 1.7-fold (0.22 log units), on the high side; low and high end bracket the measured number.
By their numbers in this assay, from the lowest: compound 2; then compounds 4 and 3 (each within the scatter of the next). At a limit, above all of these: compound 1.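

Iodo and methylsulfanyl on this aromatic carbon cannot be told apart in this assay, with a 1.2-fold lower number from compound 3 to compound 4 (0.07 log units; within the scatter), so a group without sulfur can stand in for the small sulfur group at this position. Only the (3-methoxyphenyl)sulfanyl group stands apart among the three groups seen here, with a 100-fold higher number from compound 2 to compound 4 (2.00 log units; beyond the scatter), a step of about the same size as a 120-fold higher number from compound 2 to compound 3 (2.07 log units; beyond the scatter), so a sulfur on this carbon does not by itself go with the low number. A second place in the molecule also counts, since tert-butyl in place of amino on an aromatic carbon gives an at least 33-fold lower number from compound 1 to compound 4 (1.52 log units; beyond the scatter), and this step starts from a limit of the assay, not a number: the limit of > 1000000 nM in this assay, at which 1 of the 4 values shown sits.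

As far as these compounds go, it stays open whether other small groups on this carbon, such as chloro, methoxy or an amine, would also fall in with compound 3 and compound 4. From the compounds shown here alone, it is equally open whether a plain phenyl on the sulfur, without the methoxy, would keep the number of compound 2 at 300 nM, or whether a longer chain on the sulfur would come close to it.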